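The source may hold more compounds than are shown below. What is called first, only, known or untested is meant among the compounds shown, and "the series" means these compounds.

Working notes on the series, read-out a functional assay on ECV-304 cells (Homo sapiens) for cytotoxicity; on this read-out lower numbers stand for stronger inhibition and higher numbers for weaker inhibition; each value below is a limit of the assay and not a number.

- compound 1 `Cc1ccc(/C=C2\SC(=S)N(NS(=O)(=O)c3ccccc3)C2=O)cc1`: > 50000 nM
- compound 2 `Cc1cccc(/C=C2\SC(=S)N(NS(=O)(=O)c3ccccc3)C2=O)c1`: > 50000 nM
- compound 3 `COc1cccc(/C=C2\SC(=S)N(NS(=O)(=O)c3ccccc3)C2=O)c1`: > 50000 nM

Not yet measured: compound 4 `O=C1/C(=C/c2ccccc2F)SC(=S)N1NS(=O)(=O)c1ccccc1`.

Compound 3 gives > 50000 nM, which is a limit. It has no rank within the series, and the whole set sits together: the limit of > 50000 nM in this assay, at which 3 of the 3 values shown sit.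

The next step is 2-fluorophenyl in place of 3-methoxyphenyl on a double-bonded chain carbon bound to a double-bonded ring carbon. In words, this is 2-fluorophenyl in place of 3-methoxyphenyl on a double-bonded chain carbon bound to a double-bonded ring carbon.

For the measured compounds named here, three measured steps bear on this change, as all of them alter the same aryl group: a step that the two limits leave unreadable from compound 1 to compound 2, a step that the two limits leave unreadable from compound 1 to compound 3 and a step that the two limits leave unreadable from compound 2 to compound 3. Going by the values given here, none of them has a readable size, and no measured compound carries 2-fluorophenyl.

The expectation therefore rests on compound 3 and its step that the two limits leave unreadable from compound 1 to compound 3, together with the limit of > 50000 nM in this assay, at which 3 of the 3 values shown sit. No step beyond the scatter is expected in this assay, no direction can be given, and another report as a limit is the likely outcome. The estimated step is a number no higher from compound 3 to compound 4 (the limit leaves the size open). Compound 4 is estimated at 50000 nM, with an expected range from 20000 nM to 100000 nM.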

Compound 4, half-maximal inhibitory concentration: > 50000 nM
Compound 4 gave a limit, no number; the forecaster's own chance of this, stated with the estimate: 80%; the middle value sits exactly at the limit.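

In this assay compound 4 gives > 50000 nM, which is a limit. No step between compound 4 and compound 1, compound 2 or compound 3 can be read, and the series stays together: the limit of > 50000 nM in this assay, at which 4 of the 4 values shown sit.

The compounds shown leave open whether any aryl group at this place gives a numerical value in this assay, and how the four compounds would rank.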